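Methoxy Added to a Second Core

The source may hold more compounds than are shown below. What is called first, only, known or untested is meant among the compounds shown, and "the series" means these compounds.

Compound 1 `C=C(C)[C@@H]1CC=C(Cn2cc(COc3cccc(C4NC(=O)NC(C)=C4C(=O)OCC)c3)nn2)CC1` shows no measurable growth inhibition in a functional assay on PC-3 cells (Homo sapiens) for inhibition, read by sulforhodamine B assay, with a stated time of 48 h (on this read-out lower numbers stand for stronger inhibition of growth and higher numbers for weaker inhibition of growth), where compound 1 gives > 100000 nM, a limit of the assay rather than a number. Compound 2 `C=C(C)[C@@H]1CC=C(Cn2cc(COc3cc(C4NC(=O)NC(C)=C4C(=O)OCC)ccc3OC)nn2)CC1` differs by methoxy in place of hydrogen on an aromatic carbon. In this assay compound 2 likewise reaches only a limit, > 100000 nM. The step that the two limits leave unreadable from compound 1 to compound 2 remains unreadable because of the limit of > 100000 nM in this assay, at which 2 of the 3 values shown sit. Compound 3 `C=C(C)[C@@H]1CC=C(Cn2cc(COc3cccc(C4NC(=O)NC5=C4C(=O)CC(C)(C)C5)c3)nn2)CC1` is built on another core; how that core differs from the core of compound 1 is not broken down here. In this assay compound 3 gives 21900 nM. Compound 4 `C=C(C)[C@@H]1CC=C(Cn2cc(COc3cc(C4NC(=O)NC5=C4C(=O)CC(C)(C)C5)ccc3OC)nn2)CC1` applies the same change to compound 3: methoxy in place of hydrogen on an aromatic carbon. For the measured compounds named here, the one measured instance of this change gave no readable size. The step expected for compound 4 is a 1.1-fold higher number from compound 3 to compound 4 (0.06 log units; within the scatter), close to no change. Compound 4 is therefore estimated at 25000 nM, between 8000 nM and 100000 nM.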

Compound 4, concentration for total growth inhibition: 79900 nM
Compound 4: the middle estimate sits 3.2-fold (0.50 log units) below what was measured; measured number inside the range.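

In this assay, methoxy in place of hydrogen on an aromatic carbon gives a 3.6-fold higher number from compound 3 to compound 4 (0.56 log units; beyond the scatter), so on the core of compound 3 this change weakens growth inhibition by a step beyond the scatter. It does not show whether that step carries over between cores, because the same change on the core of compound 1 cannot be read: the limit of > 100000 nM in this assay, at which 2 of the 4 values shown sit. For the compounds shown here, the one readable step therefore describes this single pair and no wider trend.

The compounds shown leave open how hydroxyl or ethoxy would compare with methoxy at the same place on the core of compound 3. They also leave open whether a carboxylic acid in place of the ethyl ester would give the core of compound 1 a readable value.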